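This account rests on a few compounds, and the source may have more. Where it says the series, first, only, none or still open, it means among the compounds named here.

Of the compounds shown here, three built on a shared core have been measured in a functional assay on SF-268 cells (Homo sapiens); a higher number here means a weaker inhibitor of growth, a lower number a stronger inhibitor of growth. Compound 1 `COc1cc(CSc2cc(Cl)c(-c3nnc(-c4ccc(Cl)cc4)s3)cc2S(=O)(=O)NC(=N)NO)cc(OC)c1OC` gives 9550 nM in this assay. Compound 2 `COc1cc(CSc2cc(Cl)c(-c3nc(-c4ccccc4)no3)cc2S(=O)(=O)NC(=N)NO)cc(OC)c1OC` gives 6920 nM; the step of a 1.4-fold lower number from compound 1 to compound 2 (0.14 log units; within the scatter) comes with 3-phenyl-1,2,4-oxadiazol-5-yl in place of 5-(4-chlorophenyl)-1,3,4-thiadiazol-2-yl on an aromatic carbon. Compound 3 `N=C(NO)NS(=O)(=O)c1cc(-c2nc(-c3ccccc3)no2)c(Cl)cc1SCc1ccccc1` gives 1740 nM, and the step of a 4.0-fold lower number from compound 2 to compound 3 (0.60 log units; beyond the scatter) comes with phenyl in place of 3,4,5-trimethoxyphenyl on a saturated chain carbon bound to a sulfur. Among these three numbers compound 2 stands second highest: compound 1 lies within the scatter of it, and only compound 3 lies beyond it, on the lower side.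

Compound 4 `COc1cc(CSc2cc(Cl)c(-c3nc(-c4ccc(Cl)cc4)no3)cc2S(=O)(=O)NC(=N)NO)cc(OC)c1OC` has not yet been measured. It differs from compound 2 by chloro in place of hydrogen on an aromatic carbon. For the measured compounds named here, no measured step isolates this change. The nearest guide is a 1.4-fold lower number from compound 1 to compound 2 (0.14 log units; within the scatter), in which a chloro substituent on the outer aryl group was lost together with an exchange of the five-membered ring, and that step stayed within the scatter. The present change is smaller still, so the expected step is a 1.1-fold lower number from compound 2 to compound 4 (0.03 log units; within the scatter), none beyond the usual scatter. Compound 4 is therefore estimated at 6500 nM in this assay, with a range from 2500 nM to 16000 nM.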

Compound 4, concentration for 50% growth inhibition: 2950 nM
Compound 4: the middle estimate sits 2.2-fold (0.34 log units) above what was measured, and the stated range covers the measured number.
By their numbers in this assay, from the lowest: compounds 3 and 4 (each within the scatter of the next); then compounds 2 and 1 (each within the scatter of the next).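

In this assay, chloro in place of hydrogen on the outer six-membered aromatic ring, para to a large group, gives a 2.3-fold lower number from compound 2 to compound 4 (0.37 log units; beyond the scatter), so this position responds to a single added heavy atom by more than the scatter. With the 4-chlorophenyl group now present on both sides, the exchange of the five-membered ring can be read on its own as a 3.2-fold lower number from compound 1 to compound 4 (0.51 log units; beyond the scatter), which shows that the small earlier step, a 1.4-fold lower number from compound 1 to compound 2 (0.14 log units; within the scatter), combined two changes pulling in opposite directions that nearly cancelled. Nothing available here explains why either change lowers or raises the number.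

The compounds shown hold only hydrogen or chloro at this position, so it remains open whether a fluoro, a methyl or a methoxy group there would move the number the same way, or further. From the compounds shown here alone, it is also open whether the chloro step carries over to compound 3, which has phenyl rather than 3,4,5-trimethoxyphenyl on the chain carbon bound to sulfur, since the two changes might add up or might not.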